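A few compounds are considered here, and "the series" means these few. Any claim that something is new, unique, unknown or untested is made for them only; others in the source may bear on it.

Measured compounds:
- compound 1, `O=S1(=O)NC(NCC2CCCCC2)=Nc2ncc(Cl)cc21`: 38.2 uM
- compound 2, `C[C@@H](NC1=NS(=O)(=O)c2cc(Cl)cnc2N1)C1CCCCC1`: 3.5 uM
- compound 3, `O=S1(=O)NC(NCc2ccccc2)=Nc2ncc(Cl)cc21`: 43.6 uM

These three were tested in a functional assay (aorta) with Rattus norvegicus as the target; a lower number here means that less compound is needed, a higher number that more compound is needed for the effect. Compound 2 gives the lowest number of the three, and its gap to compound 1 and to compound 3 lies beyond the scatter. The difference between the core of compound 2 and the core of compound 1 is not broken down here. Compound 1 and compound 3 differ in one place, (phenyl in place of cyclohexyl on a saturated chain carbon bound to an amine nitrogen), and the step was a 1.1-fold higher number from compound 1 to compound 3 (0.06 log units; within the scatter).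

Compound 4, `C[C@@H](NC1=NS(=O)(=O)c2cc(Cl)cnc2N1)c1ccccc1`, is not yet measured. It differs from compound 2 by phenyl in place of cyclohexyl on a saturated chain carbon bound to an amine nitrogen and a saturated chain carbon. This is the same kind of change as that from compound 1 to compound 3, but the place is not the same word for word: in compound 2 the carbon carrying the ring is bound to an amine nitrogen and a saturated chain carbon, whereas in compound 1 it is bound only to an amine nitrogen. Because the earlier step was a 1.1-fold higher number from compound 1 to compound 3 (0.06 log units; within the scatter), a small step is expected for compound 4 as well, estimated as a 1.1-fold higher number from compound 2 to compound 4 (0.06 log units; within the scatter). Compound 4 is therefore expected to give about 4 uM in this assay, estimated within 1.8 uM to 9 uM.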

Compound 4, concentration for half-maximal effect: 38.8 uM
Beside the measured number, compound 4's estimate is 9.7-fold (0.99 log units) below it; measured number outside the range, above it.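

In this assay, replacing cyclohexyl with phenyl gave an 11-fold higher number from compound 2 to compound 4 (1.04 log units; beyond the scatter), so the change did not carry over with the same size from the earlier pair: the same change on two cores in this assay, a 1.1-fold higher number (0.06 log units; within the scatter) from compound 1 to compound 3 and an 11-fold higher number (1.04 log units; beyond the scatter) from compound 2 to compound 4, 9.7-fold (0.99 log units) apart, beyond the scatter of two such steps. This shows that, in this series, the size of the step from one pair cannot simply be transferred to another pair, even when the same two rings are exchanged. It does not show why the two steps differ: the carbon carrying the ring is bound differently in the two pairs, but two pairs cannot establish whether that alone accounts for the gap or predict the step on any further core.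

The compounds shown leave open how a cyclopentyl ring or a pyridine ring on that carbon would compare with cyclohexyl and phenyl. From the compounds shown here alone, whether a fluorine in place of the chlorine on the shared core would alter the size of the step also remains open.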